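A cyano group replaces benzyloxy on a shared core

The compounds below may be only part of what the source reports. "The series", "measured", "known", "first", "only" and "open" are said of these compounds alone.

Of the compounds shown here, three built on one core have been measured. Compound 1 `Nc1nc(O)c2c(n1)n(C1OC(CO)[C@@H](O)[C@H]1O)c(=O)n2Cc1ccc(Cl)cc1` gives 27% in a functional assay on YAC-1 cells (Mus musculus); a higher number here means a larger maximal response, a lower number a smaller maximal response. Compound 2 `N#Cc1cccc(Cn2c(=O)n(C3OC(CO)[C@@H](O)[C@H]3O)c3nc(N)nc(O)c32)c1` gives 11% in this assay, and compound 3 `Nc1nc(O)c2c(n1)n(C1OC(CO)[C@@H](O)[C@H]1O)c(=O)n2Cc1ccc(OCc2ccccc2)cc1` gives 6%. Compound 3 stands lowest of the three numbers, but its value and that of compound 2 lie within the scatter of each other, so the two cannot be ordered; only compound 1 is clearly apart from it, through a number 21 percentage points lower from compound 1 to compound 3 (beyond the scatter).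

Compound 4 `N#Cc1ccc(Cn2c(=O)n(C3OC(CO)[C@@H](O)[C@H]3O)c3nc(N)nc(O)c32)cc1` differs from compound 3 by cyano in place of benzyloxy on an aromatic carbon. Among the measured compounds shown here, two measured steps bear on this change. The step of a number 21 percentage points lower from compound 1 to compound 3 (beyond the scatter) shows that bringing in the benzyloxy group lowered the response, so its removal points upward. The step of a number 16 percentage points lower from compound 1 to compound 2 (beyond the scatter) shows that a cyanophenyl group in place of chlorophenyl also lowered the response, which caps how far compound 4 is expected to climb. Taken together, compound 4 is expected to sit between compound 3 and compound 1, a step of a number 8 percentage points higher from compound 3 to compound 4 (within the scatter) that may barely clear the scatter. In this assay compound 4 is therefore estimated at 14%, with a range from 4% to 28%.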

Compound 4, largest response reached (reported as maximal response), in percent of the reference or control that the assay uses: 0%
Beside the measured number, compound 4's estimate is 14 percentage points above it; measured number below the stated range.
By their numbers in this assay, from the lowest: compounds 4, 3 and 2 (each within the scatter of the next, the first and the last beyond it); then compound 1.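

Cyano in place of benzyloxy on this aromatic carbon, a step of a number 6 percentage points lower from compound 3 to compound 4 (within the scatter) in this assay, leaves compound 4 and compound 3 indistinguishable, so the small nitrile, like the large benzyloxy, fails to keep the response that chloro gives. Where the nitrile sits does count: the change to 4-cyanophenyl from 3-cyanophenyl gives a number 11 percentage points lower from compound 2 to compound 4 (beyond the scatter), a modest difference that compound 2 alone could not have shown. Cyano in place of chloro on the same carbon gives a number 27 percentage points lower from compound 1 to compound 4 (beyond the scatter), the largest step in the series, and compound 1 now stands clear of all three other compounds, so among the groups shown only chloro keeps a response that can be told apart from the rest.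

Nothing in the data shown accounts for these differences. As far as these compounds go, it stays open whether fluoro, bromo, methyl or methoxy on this aromatic carbon would match chloro, and whether an amine or a carboxylic acid there would give any response at all.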